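Inverting One Ring Stereocentre in a Hydroxamate Series

The source may hold more compounds than are shown below. What is called first, only, known or untested is meant among the compounds shown, and "the series" means these compounds.

Three compounds have been measured in an assay on Sf9 cells for inhibition of histone deacetylase 11 (Homo sapiens), read by fluorescence, tested at 0.5 uM; on this read-out lower numbers stand for less inhibition and higher numbers for more inhibition at the one concentration tested (going by the name of the read-out):
compound 1, `O=C(/C=C/c1cn([C@@H]2C[C@H](CO)N(CCCc3ccccc3)C2)nn1)NO`, gives 12%;
compound 2, `O=C(/C=C/c1cn([C@@H]2C[C@@H](C(=O)O)N(Cc3ccccc3)C2)nn1)NO`, gives 12%;
compound 3, `O=C(NO)c1cccc(-c2cn([C@@H]3C[C@H](CO)N(CCCc4ccccc4)C3)nn2)c1`, is reported only as a limit, < 10%.

Compound 1 and compound 2 stand level at the digits shown, within the scatter of this assay. Compound 3 sits at the limit of this assay, which is the limit of < 10% in this assay, at which 1 of the 3 values shown sits. Among the measured compounds shown here, the only step measured between two compounds that differ in one place is a number at least 2 percentage points lower from compound 1 to compound 3 (that floor lies within the scatter), and its floor lies within the scatter, so no measured step in this set shows a change beyond the scatter.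

Compound 4, `O=C(/C=C/c1cn([C@H]2C[C@H](CO)N(CCCc3ccccc3)C2)nn1)NO`, differs from compound 1 by the two compounds have the same atoms and bonds and differ only in configuration as drawn: 1 of 3 stereo elements differ; a stereocentre at a saturated ring carbon is drawn R in compound 1 and S in compound 4. For the measured compounds named here, no measured step in this assay bears directly on a change of configuration alone; the one step available, a number at least 2 percentage points lower from compound 1 to compound 3 (that floor lies within the scatter), concerns a different change and is itself small. Compound 1 is already near the floor of the read-out, so the step expected is no change at the digits printed from compound 1 to compound 4 (within the scatter). Compound 4 is therefore estimated at 12%, between 0% and 25%.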

Compound 4, a percentage reported as inhibition, at one concentration (the size of the read-out at that concentration, not a potency): 16%
Compound 4: the middle estimate sits 4 percentage points below what was measured; measured number inside the range.
By their numbers in this assay, from the lowest: compounds 1, 2 and 4 (each within the scatter of the next). At a limit, below all of these: compound 3.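

Inverting this saturated ring carbon from R to S gives a number 4 percentage points higher from compound 1 to compound 4 (within the scatter) in this assay, and this is the first step in the set that changes configuration alone. At this position and at the one concentration tested, the inversion therefore does not separate from the usual scatter of the read-out. The comparison isolates configuration at this one carbon, with nothing else altered: the fact that compounds 1 and 4 differ only in the configuration as drawn.

The compounds shown leave open whether the other two stereo elements behave in the same way, and whether a difference between the two configurations would appear at another concentration. They also leave open whether this inversion would read the same on a version of the shared core carrying an amine or a longer chain.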